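Compound 3 gains a hydroxy group

The source may report more compounds than this note shows. Statements on the series, on what has been measured and on what is new or still open speak of the compounds shown alone.

In an ADME assay on BJ cells (Homo sapiens) for cytotoxicity, with a stated time of 72 h (a lower number here means that less compound is needed, a higher number that more compound is needed for the effect), compound 3 (`CCc1ccc(-c2nc3c(c(C)nn3-c3ccccc3)c(-c3ccccc3)c2C#N)cc1`) gives > 20000 nM as a limit of the assay and not a number. Compound 1 (`CCc1ccc(-c2nc3c(c(C)nn3-c3ccccc3)c(-c3ccccc3C#N)c2C#N)cc1`) gives > 20000 nM as a limit of the assay. Compound 2 (`CCc1ccc(-c2nc3c(c(C)nn3-c3ccccc3)c(-c3ccccc3C(F)(F)F)c2C#N)cc1`) gives > 20000 nM as a limit of the assay. The series thus shows the limit of > 20000 nM in this assay, at which 3 of the 3 values shown sit, and no readable number.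

Compound 4 (`CCc1ccc(-c2nc3c(c(C)nn3-c3ccccc3)c(-c3cccc(O)c3)c2C#N)cc1`) carries hydroxy in place of hydrogen on an aromatic carbon, so that phenyl becomes 3-hydroxyphenyl (hydroxy in place of hydrogen on an aromatic carbon). Within the data shown here, three measured steps bear on this change, namely a step that the two limits leave unreadable from compound 1 to compound 2 and a step that the two limits leave unreadable from compound 1 to compound 3 and also a step that the two limits leave unreadable from compound 2 to compound 3 and none of them gives a size. No step beyond the usual scatter is therefore expected in either direction, since compound 3 holds > 20000 nM as a limit. The expected outcome in this assay is a number no higher from compound 3 to compound 4 (the limit leaves the size open) as an estimate only. Compound 4 is estimated at 20000 nM with an expected range from 10000 nM to 40000 nM and a report as a limit is likely.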

Compound 4, half-maximal effective concentration in the BJ assay: > 20000 nM
Compound 4: a limit, no number; the forecaster's own chance of this, stated with the estimate: 80%; the middle value lies on the limit itself.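

In the BJ assay compound 4 again gives > 20000 nM, a limit of the assay and not a number. Its steps from compound 1, compound 2 and compound 3 cannot be read. The compounds shown leave open the concentration at which any of them reaches the half-maximal effect: the limit of > 20000 nM in the BJ assay, at which 4 of the 4 values shown sit.

In a physicochemical assay for solubility, read by spectrophotometry, in phosphate buffer, with a stated time of 18 h, at pH 7.4 (on this read-out lower numbers stand for lower solubility and higher numbers for higher solubility), compound 3 gives 47000 nM and compound 4 gives 18000 nM. In the physicochemical assay the change of hydrogen to hydroxy is a 2.6-fold lower number from compound 3 to compound 4 (0.42 log units; beyond the scatter).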